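The compounds below may be only part of what the source reports. "The series", "measured", "known", "first", "only" and "open" are said of these compounds alone.

Measured in a functional assay on SK-OV-3 cells (Homo sapiens) for cytotoxicity, read by MTT assay, with a stated time of 48 h (on this read-out lower numbers stand for stronger inhibition and higher numbers for weaker inhibition), so far
compound 1 (`COc1cc(-c2ocnc2-c2cc(Br)c(OC)c(OC)c2)ccc1SC`) gives 1030 nM
compound 2 (`COc1cc(-c2ocnc2-c2cc(OC)c(OC)c(OC)c2)ccc1SC`) gives 1480 nM
compound 3 (`COc1ccc(-c2ocnc2-c2cc(OC)c(SC)c(OC)c2)cc1O`) gives 250 nM

Compound 1 sits among the higher numbers, and compound 3 lies lower, beyond the scatter. The closest neighbour shows a 1.4-fold higher number from compound 1 to compound 2 (0.16 log units; within the scatter) as the gap.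

The change to compound 4 (`COc1ccc(-c2ocnc2-c2cc(Br)c(OC)c(OC)c2)cc1OC`) is this one (methoxy in place of methylsulfanyl on an aromatic carbon), methoxy in place of methylsulfanyl on an aromatic carbon, ortho to a methoxy group and para to a large group. Among the measured compounds shown here, no measured step covers this exchange. For the measured compounds named here, the only measured step, methoxy in place of bromo, is a different exchange and bears on it only loosely, at a 1.4-fold higher number from compound 1 to compound 2 (0.16 log units; within the scatter) and within the scatter. Going by the values given here, compound 3 differs from compound 1 in more than one place and gives no single step.

In this assay, going by these compounds, no step beyond the scatter is expected, and the direction stays open. The estimated step is (a 1.3-fold higher number from compound 1 to compound 4 (0.10 log units; within the scatter)). For compound 4 the estimated value is 1300 nM with an expected range from 350 nM to 5000 nM and the range is kept wide.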

Compound 4, half-maximal inhibitory concentration: 260 nM
The estimate for compound 4 lay 5.0-fold (0.70 log units) above the measured number; the measured number lies below the stated range.
By their numbers in this assay, from the lowest: compounds 3 and 4 (each within the scatter of the next); then compounds 1 and 2 (each within the scatter of the next).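

In this assay this position, on an aromatic carbon ortho to a methoxy group and para to a large group, responds to the exchange: methoxy in place of methylsulfanyl gives a 4.0-fold lower number from compound 1 to compound 4 (0.60 log units; beyond the scatter) in the series. The other single exchange, methoxy in place of bromo, gives only a 1.4-fold higher number from compound 1 to compound 2 (0.16 log units; within the scatter) and so did not show a site where one change moves the number beyond the scatter. The two groups match in heavy-atom count and in hydrogen-bond donors and acceptors, and no measurement here accounts for the step.

Going by these compounds, whether the same exchange gives a similar step with methoxy instead of bromo on the other ring remains open. On these data alone, how an amine or an ethoxy group would read at this position also remains open.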